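A few compounds are considered here, and "the series" means these few. Any claim that something is new, unique, unknown or untested is made for them only; others in the source may bear on it.

In a functional assay on NCI-H460 cells (Homo sapiens) for inhibition, read by MTT assay, with a stated time of 4 days (on this read-out lower numbers stand for stronger inhibition and higher numbers for weaker inhibition), the measured compounds read as follows
- compound 1 `COc1cc(NC(C)CCCNC(=O)NNC(=O)NCCCCCO)c2ncccc2c1` gives > 100000 nM as a limit
- compound 2 `CCOC(=O)N(C)C(c1ccccc1)c1ccccc1` gives >= 100000 nM as a limit
- compound 3 `COc1cc(NC(C)CCCNC(=O)NCCNC(c2ccccc2)(c2ccccc2)c2ccccc2)c2ncccc2c1` gives > 100000 nM as a limit

Compound 1 stands at the limit of > 100000 nM in this assay, at which 2 of the 3 values shown sit, and gives no number. None of the three measured compounds gives a number, so no measured step can be read. Compound 4 `COc1cc(NC(C)CCCNC(=O)Nc2ccc(Cl)c(C(F)(F)F)c2)c2ncccc2c1` carries 4-chloro-3-(trifluoromethyl)phenyl in place of ((5-hydroxypentyl)carbamoyl)amino on an amide-type nitrogen. In this assay a step beyond the scatter towards stronger inhibition is expected, though with little support from limits alone. The expected change is an at least 8.3-fold lower number from compound 1 to compound 4 (0.92 log units; beyond the scatter) and is set against a limit. For compound 4 the estimate is 12000 nM with an expected range from 2500 nM to 60000 nM in this read-out.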

Compound 4, half-maximal inhibitory concentration: 28000 nM
Beside the measured number, compound 4's estimate is 2.3-fold (0.37 log units) below it, within the range that was stated.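

In this assay, compound 4 is the only compound shown that gives a number rather than a limit, so this amide-type nitrogen tolerates a change that registers in the read-out. Placing 4-chloro-3-(trifluoromethyl)phenyl there in place of ((5-hydroxypentyl)carbamoyl)amino gives an at least 3.5-fold lower number from compound 1 to compound 4 (0.55 log units; beyond the scatter). That step starts from a limit, so only its minimum size can be read: the limit of > 100000 nM in this assay, at which 2 of the 4 values shown sit.

The compounds shown do not separate the contribution of the aromatic ring from that of its chlorine and trifluoromethyl substituents. From the compounds shown here alone, whether an unsubstituted phenyl or a carboxylic acid on a longer chain at this nitrogen would behave similarly remains open.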